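From triazole to methylimidazole on a shared core

The source may report more compounds than this note shows. Statements on the series, on what has been measured and on what is new or still open speak of the compounds shown alone.

In a physicochemical assay for lipophilicity, at pH 7.4 (on this read-out higher numbers stand for higher lipophilicity and lower numbers for lower lipophilicity), compound 1 (`CC(C)Oc1ccc(-c2nnc(-n3cncn3)s2)cc1Cl`) gives 6.18, the highest of the three numbers in hand. Compound 2 (`CC(C)Oc1ccc(-c2nnc(-n3cc4c(n3)CCN(CCCC(=O)O)C4)s2)cc1Cl`) gives 3.56 and compound 3 (`Cc1nn(-c2nnc(-c3ccc(OC(C)C)c(Cl)c3)s2)c(C)c1CC(=O)O`) gives 3.62, each lying beyond the scatter under compound 1. Compound 4 (`CC(C)Oc1ccc(-c2nnc(-c3cncn3C)s2)cc1Cl`) keeps the core of compound 1 and swaps a single group, with 1-methyl-1H-imidazol-5-yl in place of 1H-1,2,4-triazol-1-yl on an aromatic carbon. Going by the values given here, no measured pair shows this swap, so the expectation rests on the structural change alone. A modest fall in this assay is expected, and it may not clear the scatter. The estimated step is a number 0.48 log units lower from compound 1 to compound 4 (beyond the scatter). For compound 4 the expected value is 5.7, within an estimated range of 5 to 6.3.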

Compound 4, distribution coefficient: 5.7
Estimate against measurement, compound 4: no gap at the digits printed, within the range that was stated.
By their numbers in this assay, from the lowest: compounds 2 and 3 (each within the scatter of the next); then compound 4; then compound 1.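

Going by these compounds alone, on the shared core, 1-methyl-1H-imidazol-5-yl in place of 1H-1,2,4-triazol-1-yl on an aromatic carbon gives the first step in one place in this assay, a modest one: a number 0.48 log units lower from compound 1 to compound 4 (beyond the scatter). It shows that exchanging one five-membered aromatic ring for another at this position moves the read-out beyond the scatter. No measurement in hand accounts for the size of this step. Still open, on these data alone, is how an amine or a carboxylic acid on the 1-methyl-1H-imidazol-5-yl ring would read. As far as these compounds go, a longer chain in place of its methyl is equally open.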